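The source may report more compounds than this note shows. Statements on the series, on what has been measured and on what is new or still open speak of the compounds shown alone.

The cell read-out used throughout comes from an ADME assay on HEK-293T cells (Homo sapiens) for cytotoxicity, read by MTT assay, tested at 25 uM; on this read-out lower numbers stand for a stronger effect and higher numbers for a weaker effect at the one concentration tested. Compound 3 `O=C(Nc1ncc([N+](=O)[O-])s1)c1ccc(-c2ccc(Cl)cc2)o1` carries a chloro group, and in this assay compound 3 gives 75%. This is the highest of the two numbers available here: compound 2 `CC(=O)Oc1c(C(=O)Nc2ncc([N+](=O)[O-])s2)cc(C(C)C)cc1C(C)C` gives 45.9% in this assay, a number lower by a gap that lies beyond the usual scatter, so compound 2 acts more strongly on the cells than compound 3 does. Compound 1 `O=C(Nc1ncc([N+](=O)[O-])s1)c1ccc(Cl)cc1O` gives "not determined" (no result reported) in this assay, so nothing can be said of it.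

The next compound, compound 4 `COOc1ccc(-c2ccc(C(=O)Nc3ncc([N+](=O)[O-])s3)o2)cc1`, differs from compound 3 in one place: methoxyoxy in place of chloro on an aromatic carbon. For the measured compounds named here, no pair of measured compounds here differs by a single change, so there is no measured step to lean on. Given that compound 3 shows a weak effect in this assay at 75%, the expected step is a number 3 percentage points lower from compound 3 to compound 4 (within the scatter), which is to say none beyond the scatter. For compound 4 the estimated result in this assay is 72%, with a range from 52% to 90%.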

Compound 4, a percentage reported as activity, at one concentration (the size of the read-out at that concentration, not a potency): 100%
Compound 4: middle estimate off by 28 percentage points, on the low side; measured number outside the range, above it.
By their numbers in this assay, from the lowest: compound 2; then compound 3; then compound 4.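

Putting methoxyoxy in place of chloro on this aromatic carbon, para to a large group, gives a number 25 percentage points higher from compound 3 to compound 4 (beyond the scatter) in this assay. For the compounds shown here, this is the one measured step so far, and it shows that a single change at this place can shift the read-out: higher numbers mean a weaker effect, so compound 4 acts more weakly on the cells than compound 3. The compounds shown offer no measurement that explains the shift.

One pair cannot tell whether the loss of chloro or the arrival of methoxyoxy matters more. As far as these compounds go, it also remains open how the read-out would respond to a different group at this place, such as an amine, a carboxylic acid or a longer chain.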